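Second fluoro on the benzamide ring: compound 4

This account rests on a few compounds, and the source may have more. Where it says the series, first, only, none or still open, it means among the compounds named here.

The series shares one core carrying an amide-linked aryl group, varied only at the carbonyl-bound ring. Compound 1 `O=C(Nc1cccc(-c2oc3cc(-c4ccc(F)cc4)ccc3c(=O)c2O)c1)c1ccccc1F` carries a 2-fluorophenyl there and gives 7570 nM in a functional assay on MCF7 cells (Homo sapiens) for antiproliferative activity, read by CCK-8 assay, with a stated time of 72 h; a higher number here means a weaker inhibitor, a lower number a stronger inhibitor. Compound 2 `COc1ccc(C(=O)Nc2cccc(-c3oc4cc(-c5ccc(F)cc5)ccc4c(=O)c3O)c2)cc1` carries a 4-methoxyphenyl and gives 6250 nM. Compound 3 `O=C(Nc1cccc(-c2oc3cc(-c4ccc(F)cc4)ccc3c(=O)c2O)c1)c1cccc(F)c1` carries a 3-fluorophenyl and gives 5770 nM. The three numbers sit together: a 1.2-fold lower number from compound 1 to compound 2 (0.08 log units; within the scatter), a 1.3-fold lower number from compound 1 to compound 3 (0.12 log units; within the scatter) and a 1.1-fold lower number from compound 2 to compound 3 (0.03 log units; within the scatter), so none of the three aryl replacements separates from the others beyond the scatter, and compound 3 stands among them rather than apart from them.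

Compound 4 `O=C(Nc1cccc(-c2oc3cc(-c4ccc(F)cc4)ccc3c(=O)c2O)c1)c1cc(F)cc(F)c1` is not yet measured. It differs from compound 3 by fluoro in place of hydrogen on an aromatic carbon. The bearing steps are those that moved or swapped a single substituent on this ring, namely from compound 1 to compound 2, from compound 1 to compound 3 and from compound 2 to compound 3, all within the scatter. Adding a second fluoro to the ring that already carries one is therefore expected to leave the number where it is, with no step beyond the scatter in either direction. For compound 4 the expected step is a 1.0-fold lower number from compound 3 to compound 4 (0.02 log units; within the scatter). The estimate for compound 4 is 5500 nM, with a range from 2700 nM to 11000 nM.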

Compound 4, half-maximal inhibitory concentration: 2490 nM
Estimate against measurement, compound 4: 2.2-fold (0.34 log units) above, and the stated range ends above it.
By their numbers in this assay, from the lowest: compound 4; then compounds 3, 2 and 1 (each within the scatter of the next).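

In this assay, within the data shown here, the second fluoro is the first change on this ring to move the number beyond the scatter, with a 2.3-fold lower number from compound 3 to compound 4 (0.36 log units; beyond the scatter), a modest step, whereas the swaps among the 2-fluorophenyl, 3-fluorophenyl and 4-methoxyphenyl rings stayed within it. The 3,5-difluorophenyl ring also separates from the two other rings, with a 2.5-fold lower number from compound 2 to compound 4 (0.40 log units; beyond the scatter) and a 3.0-fold lower number from compound 1 to compound 4 (0.48 log units; beyond the scatter), which makes compound 4 the most potent of the four compounds here, though still by modest steps. Nothing shown bears on why adding this fluoro moves the number.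

The compounds shown leave open whether the shift belongs to the 3,5-difluorophenyl ring as such or to the presence of two fluoro groups on the ring, as no other difluorophenyl arrangement stands beside compound 4. They also leave open whether the fluoro itself is needed, since a 3,5-dichlorophenyl, a 3,5-dimethylphenyl or a ring carrying a nitrile or an amine at the same places would test how far the shift depends on this particular substituent.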